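Fluoro in place of hydrogen, starting from a limit

The source may hold more compounds than are shown below. What is called first, only, known or untested is meant among the compounds shown, and "the series" means these compounds.

In a functional assay on MT2 cells (Homo sapiens) for antiproliferative activity, read by MTT assay, with a stated time of 72 h (on this read-out lower numbers stand for stronger inhibition of growth and higher numbers for weaker inhibition of growth), compound 1 (`O=C(COc1ccc2c(=O)cc(-c3ccccc3)oc2c1)Nc1ccc2ccccc2c1`) gives > 10000 nM as a limit of the assay and not a number. Compound 2 (`O=C(COc1ccc2c(=O)cc(-c3ccccc3)oc2c1)Nc1ccccc1`) likewise gives > 10000 nM as a limit. Compound 2 therefore has no readable position, and the evidence so far is only the limit of > 10000 nM in this assay, at which 2 of the 2 values shown sit (no value has yet fallen inside the measurable range). Among the measured compounds shown here, the one measured step (a step that the two limits leave unreadable from compound 1 to compound 2) puts phenyl in place of naphthalen-2-yl on an amide-type nitrogen, and its size cannot be read.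

Compound 3 (`O=C(COc1ccc2c(=O)cc(-c3ccccc3)oc2c1)Nc1ccc(F)cc1`) changes the phenyl of compound 2 to 4-fluorophenyl, with fluoro in place of hydrogen on an aromatic carbon, para to a large group (fluoro in place of hydrogen on an aromatic carbon). For the measured compounds named here, no measured step gives a size to carry over to this change, so no step beyond the scatter is expected in this assay, and a further limit is the likeliest report. The expected step (a step that the limit leaves unreadable from compound 2 to compound 3) is only a rough estimate. Compound 3 is estimated at 12000 nM with an expected range from 5000 nM to 20000 nM in this estimate.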

Compound 3, concentration for 50% growth inhibition: 6410 nM
Beside the measured number, compound 3's estimate is 1.9-fold (0.27 log units) above it; measured number inside the range.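

With fluoro on an aromatic carbon, para to a large group, compound 3 gives 6410 nM in this assay, the only number among the three compounds shown, so changes at this position can now be followed on a measurable scale. The change itself is bounded from one side only, as an at least 1.5-fold lower number from compound 2 to compound 3 (0.19 log units; that floor lies within the scatter), and the same holds for 4-fluorophenyl in place of naphthalen-2-yl, as an at least 1.5-fold lower number from compound 1 to compound 3 (0.19 log units; that floor lies within the scatter), so neither step is shown to go beyond the scatter. The true size of both steps stays unknown, since each starts from a limit and not from a number: the limit of > 10000 nM in this assay, at which 2 of the 3 values shown sit.

The compounds shown leave open whether chloro, methoxy or an amine on this same carbon would also give a number inside the measurable range, and whether fluoro would read the same on another carbon of this ring. They also leave open whether a change to the shared core or to the chain carrying the amide would move the number of compound 3.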